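A few compounds are considered here, and "the series" means these few. Any claim that something is new, unique, unknown or untested is made for them only; others in the source may bear on it.

Compound 1 `COc1ccc(C2=C(c3cc(OC)c(OC)c(OC)c3)C(=O)C(OC(C)=O)C2)cc1` and compound 2 `COc1ccc(C2=C(c3cc(OC)c(OC)c(OC)c3)C(=O)C(O)C2)cc1` share one core. In an ADME assay on ECV-304 cells (Homo sapiens) for cytotoxicity, read by MTT assay, with a stated time of 72 h (on this read-out lower numbers stand for stronger inhibition and higher numbers for weaker inhibition), compound 1 gives 18 ug/mL. Compound 2 gives < 1 ug/mL, which is a limit of the assay and not a number, so it stands only at that limit. Compound 3 `COc1ccc(C2=C(c3cc(OC)c(OC)c(OC)c3)C(=O)C(O[SiH2]C(C)(C)C)C2)cc1` differs from compound 2 by a group of 5 heavy atoms (4 carbon, 1 silicon; no ring) in place of a hydrogen atom, on an oxygen on a saturated carbon. Among the compounds with values here, the only measured step that bears on this is an at least 18-fold lower number from compound 1 to compound 2 (1.25 log units; beyond the scatter), with hydrogen in place of acetyl on the same oxygen. A large move to a higher number is therefore expected in this assay, though the entering group is not acetyl. The expected step is an at least 8.0-fold higher number from compound 2 to compound 3 (0.90 log units; beyond the scatter). Compound 3 is estimated at 8 ug/mL, with a range of 1.5 ug/mL to 40 ug/mL.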

Compound 3, half-maximal inhibitory concentration: 16 ug/mL
For compound 3 the middle estimate is 2.0-fold (0.30 log units) below the measured one, within the range that was stated.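

In this assay, within the data shown here, acetyl is not the only group on this oxygen that goes with a large move away from the free hydrogen: an at least 16-fold higher number from compound 2 to compound 3 (1.20 log units; beyond the scatter). The two groups tested here read alike, with a 1.1-fold lower number from compound 1 to compound 3 (0.05 log units; within the scatter), so the group of 5 heavy atoms (4 carbon, 1 silicon; no ring) and acetyl cannot be told apart. Compound 2 stands at a limit and not at a number: the limit of < 1 ug/mL in this assay, at which 1 of the 3 values shown sits.

On these data alone, the true size of the step from the free hydrogen stays open. So does whether a methyl or a benzyl group on this oxygen would read like these two.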